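Diterpenoid lactone series: acetate removal at the ring hydroxyl

A few compounds are considered here, and "the series" means these few. Any claim that something is new, unique, unknown or untested is made for them only; others in the source may bear on it.

Measured compounds:
compound 1 `C=C1CC[C@@H]2[C@](C)(CO[Si](C)(C)C(C)(C)C)[C@H](O)CC[C@@]2(C)[C@@H]1C/C=C1/C(=O)OC[C@H]1O`, 48.8 uM
compound 2 `C=C1CC[C@@H]2[C@](C)(CO[Si](c3ccccc3)(c3ccccc3)C(C)(C)C)[C@H](OC(C)=O)CC[C@@]2(C)[C@@H]1C/C=C1/C(=O)OC[C@H]1OC(C)=O`, 52.9 uM
compound 3 `C=C1CC[C@@H]2[C@](C)(CO[Si](C)(C)C(C)(C)C)[C@H](OC(C)=O)CC[C@@]2(C)[C@@H]1C/C=C1/C(=O)OC[C@H]1O`, 9.62 uM

The three measured compounds share one core and differ only in the groups on the two oxygens and on the silyl protecting group. In a functional assay on Lu1 cells (Homo sapiens) for cytotoxicity, read by sulforhodamine B assay (on this read-out lower numbers stand for an effect already at smaller amounts and higher numbers for an effect only at larger amounts of compound), compound 3 gives 9.62 uM, compound 1 gives 48.8 uM and compound 2 gives 52.9 uM. The values of compound 1 and compound 2 lie within the scatter of each other, so no order between them is claimed.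

One change is seen directly: hydrogen in place of acetyl on an oxygen on a saturated carbon. This change is measured once, a 5.1-fold higher number from compound 3 to compound 1 (0.71 log units; beyond the scatter), so the acetyl at that position goes along with the lower number among these three compounds.

Compound 4 `C=C1CC[C@@H]2[C@](C)(CO[Si](c3ccccc3)(c3ccccc3)C(C)(C)C)[C@H](O)CC[C@@]2(C)[C@@H]1C/C=C1/C(=O)OC[C@H]1OC(C)=O` is not yet measured. It arises from compound 2 by hydrogen in place of acetyl on an oxygen on a saturated carbon, at the same place as the change from compound 3 to compound 1. The difference between the core of compound 2 and the core of compound 3 is not broken down here; compound 2 carries the diphenyl silyl group and a second acetyl on the lactone hydroxyl, so the step is only expected to be of the same kind, not necessarily of the same size.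

Among the measured compounds shown here, for compound 4 in this assay a step of about a 3.4-fold higher number from compound 2 to compound 4 (0.53 log units; beyond the scatter) is expected, resting on the single earlier step of a 5.1-fold higher number from compound 3 to compound 1 (0.71 log units; beyond the scatter) and on compound 2 at 52.9 uM. On that basis compound 4 is estimated at 180 uM, with a range from 70 uM to 450 uM; the higher starting number of compound 2 makes a reported limit rather than a number a real possibility.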

Compound 4, concentration for half-maximal effect: 11.9 uM
Compound 4: middle estimate off by 15-fold (1.18 log units), on the high side; measured number below the stated range.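

In this assay, the change from acetoxy to hydroxy on the saturated ring carbon gives a 4.4-fold lower number from compound 2 to compound 4 (0.65 log units; beyond the scatter), so on this core the acetyl goes along with the higher number. Set beside the earlier step, the same change runs in opposite directions on the two cores, and the gap between the two steps is larger than scatter would account for: the same change on two cores in this assay, a 5.1-fold higher number (0.71 log units; beyond the scatter) from compound 3 to compound 1 and a 4.4-fold lower number (0.65 log units; beyond the scatter) from compound 2 to compound 4, 23-fold (1.35 log units) apart, beyond the scatter of two such steps

Among the compounds shown here, this shows that neither the direction nor the size of the step carries over from one of these cores to the other, although it rests on only one step per core and gives no rule for any further core. It does not show which difference between the cores goes with the reversal, the diphenyl silyl group or the second acetyl on the lactone hydroxyl, since the two differences occur together in the compounds compared.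

Separating those two differences would need a compound carrying only one of them, so that question stays open. Also open, on these data alone, is how a longer acyl chain such as butanoyl on the same oxygen, or a free hydroxyl in place of the silyl ether, would read.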